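This account rests on a few compounds, and the source may have more. Where it says the series, first, only, none or still open, it means among the compounds named here.

In a functional assay on DU-145 cells (Homo sapiens) for inhibition, read by trypan blue exclusion, with a stated time of 96 h (a higher number here means a weaker inhibitor of growth, a lower number a stronger inhibitor of growth), compound 1 `O=C(/C(=C\c1c[nH]c2ccccc12)SCc1ccc(F)cc1)c1ccc(Cl)cc1` gives 1000 nM and stands level with compound 2 `Cc1ccc(S(=O)(=O)/C(=C/c2ccc(Oc3ccccc3)cc2)C(=O)c2ccc(Cl)cc2)cc1`, which gives 1000 nM as well, so the two sit within the usual scatter of each other. Compound 3 `Cc1ccc(/C=C(/SCc2ccc(F)cc2)C(=O)c2ccc(Cl)cc2)s1` has not been measured yet. It differs from compound 1 in one place, with 5-methylthiophen-2-yl in place of 1H-indol-3-yl on a double-bonded chain carbon bound to a double-bonded chain carbon. Among the measured compounds shown here, no measured pair shows what this swap does, so the expectation in this assay is only a small step toward weaker growth inhibition, meaning a somewhat higher number, and perhaps nothing beyond the scatter. The expected step is a 1.8-fold higher number from compound 1 to compound 3 (0.26 log units; within the scatter) in size. Compound 1 at 1000 nM is the only close reference for this. Compound 3 is therefore estimated at 1800 nM with an expected range from 500 nM to 6000 nM for now.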

Compound 3, concentration for 50% growth inhibition: > 100000 nM
Compound 3: a limit, no number (the forecaster's own chance of this, stated with the estimate: 10%); middle value at least 55-fold (1.74 log units) away from the limit.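

Among the compounds shown here, the group on this double-bonded chain carbon turns out to matter greatly in this assay, which the earlier compounds could not show because no measured pair differed there. Putting 5-methylthiophen-2-yl in place of 1H-indol-3-yl gives an at least 100-fold higher number from compound 1 to compound 3 (2.00 log units; beyond the scatter), so this single change is enough to lose nearly all measurable growth inhibition. The result for compound 3 is a limit of the assay and not a number, so the full size of the step stays unknown: the limit of > 100000 nM in this assay, at which 1 of the 3 values shown sits.

The swap changes several things at once, removing the six-membered aromatic ring and the hydrogen-bond donor while adding sulfur and a methyl group, and the compounds shown cannot separate these. A 1-methyl-1H-indol-3-yl or a plain phenyl group at this place would help to tell which of these changes counts.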